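A few compounds are considered here, and "the series" means these few. Any claim that something is new, unique, unknown or untested is made for them only; others in the source may bear on it.

For the measured compounds named here, compound 2 `N#Cc1ccc(Nc2nc(N)nc(Oc3ccc4ccccc4c3Br)n2)cc1` gives in an ADME assay on MT4 cells (Homo sapiens) for cytotoxicity, read by MTT assay, with a stated time of 4 days (on this read-out higher numbers stand for lower toxicity in this test and lower numbers for higher toxicity in this test), a half-maximal cytotoxic concentration of 133000 nM, the only full number among the values shown. Compound 1 `CC(C)Nc1nc(Nc2ccc(C#N)cc2)nc(Oc2ccc3cc(Br)ccc3c2Br)n1` in this assay reaches only a limit of the assay, >= 209000 nM. Compound 3 `N#Cc1ccc(Nc2nc(N)nc(Oc3ccc4cc(Br)ccc4c3Br)n2)cc1` differs from compound 2 by bromo in place of hydrogen on an aromatic carbon. Going by the values given here, no measured pair shows this change alone, so the step expected for it in this assay is small, leaning toward lower toxicity, a 1.2-fold higher number from compound 2 to compound 3 (0.08 log units; within the scatter), and within the usual scatter. The value expected for compound 3 in this assay is 160000 nM, between 80000 nM and 320000 nM.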

Compound 3, half-maximal cytotoxic concentration: 244000 nM
Compound 3: the middle estimate sits 1.5-fold (0.18 log units) below what was measured; low and high end bracket the measured number.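

In this assay, for the compounds shown here, bromo in place of hydrogen on an aromatic carbon gives a 1.8-fold higher number from compound 2 to compound 3 (0.26 log units; within the scatter), the first step here that changes one place only. This step stays within the usual scatter, so at this place on the ring, the added bromo leaves no readable change in this test. The step between compound 1 and compound 3 cannot be read because compound 1 stands at a limit of the assay: the limit of >= 209000 nM in this assay, at which 1 of the 3 values shown sits.

The compounds shown leave open how an amine, a carboxylic acid or a longer chain at this same place would read.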